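Swapping Methoxy for Iodo in a Plant Assay

The source may report more compounds than this note shows. Statements on the series, on what has been measured and on what is new or still open speak of the compounds shown alone.

Three ureas have so far been tested in an ADME assay on the whole organism with Oryza sativa as the target, tested at 0.1 uM; a higher number here means a weaker effect of the compound at the concentration tested, a lower number a stronger effect. Compound 1 `CCc1ccccc1NC(=O)N[C@H](C)c1ccccc1` gives 101%. Compound 2 `COc1cccc(NC(=O)N[C@H](C)c2ccccc2)c1` gives 104%, and compound 3 `COc1cccc(NC(=O)N[C@@H](C)c2ccccc2)c1` gives 101%. Going by the values given here, the only measured pair that differs in one place is the step of a number 3 percentage points lower from compound 2 to compound 3 (within the scatter), which rests on (the fact that compounds 2 and 3 differ only in the configuration as drawn); a step of that kind says nothing about exchanging a group on the ring. Compound 3 stands level with compound 1, the two together being the lowest of the three numbers, and within the scatter of compound 2.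

Compound 4 `C[C@H](NC(=O)Nc1cccc(I)c1)c1ccccc1` differs from compound 3 in one place: iodo in place of methoxy on an aromatic carbon. Among the compounds with values here, no measured step bears on this exchange, so nothing points to a move in either direction, and all three measured numbers lie close together. Compound 4 is therefore expected to sit in the same region, with an expected step of a number 1 percentage points lower from compound 3 to compound 4 (within the scatter). The estimate for compound 4 is 100%, with a range from 85% to 112%.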

Compound 4, a percentage reported as activity, at one concentration (the size of the read-out at that concentration, not a potency): 98%
Compound 4: the middle estimate sits 2 percentage points above what was measured; the range from low to high includes it.
By their numbers in this assay, from the lowest: compounds 4, 1, 3 and 2 (each within the scatter of the next).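

Putting iodo in place of methoxy on this aromatic carbon gives, in this assay, a number 3 percentage points lower from compound 3 to compound 4 (within the scatter). Going by these compounds alone, this is the first measured exchange of a group on the ring in this set, and it replaces a group of 2 heavy atoms and 1 hydrogen-bond acceptor with one of 1 heavy atom and no acceptor, yet the read-out does not separate the two compounds. Nothing available on these compounds bears on why this exchange reads as it does.

As far as these compounds go, whether an amine or a carboxylic acid on the same aromatic carbon would stand apart from compound 3 remains open. Also open, from the compounds shown here alone, is whether iodo would read the same with the chain carbon in the configuration drawn in compound 2.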